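Tetrahydroisoquinoline amide in a sulfonylpiperazine series

A few compounds are considered here, and "the series" means these few. Any claim that something is new, unique, unknown or untested is made for them only; others in the source may bear on it.

The study assesses inhibition in an ADME assay on HepG2 cells (Homo sapiens) for inhibition, with a stated time of 48 h (on this read-out higher numbers stand for an effect only at larger amounts of compound and lower numbers for an effect already at smaller amounts), across a shared core carrying a tert-butylphenylsulfonyl piperazine. Compound 1 `C[C@H](C(=O)N1CCCCC1)N1CCN(S(=O)(=O)c2ccc(C(C)(C)C)cc2)CC1` reaches only the limit of this assay, > 40000 nM. Compound 2 `CC(C(=O)N1CCC(C)(C)CC1)N1CCN(S(=O)(=O)c2ccc(C(C)(C)C)cc2)CC1` likewise reaches only the limit, > 40000 nM. Compound 2 therefore stands at the limit of > 40000 nM in this assay, at which 2 of the 2 values shown sit, together with the other value shown, so no number places it anywhere within the measured scale. Compound 3 `CC(C(=O)N1CCc2ccccc2C1)N1CCN(S(=O)(=O)c2ccc(C(C)(C)C)cc2)CC1` has not yet been measured; it differs from compound 2 by 1,2,3,4-tetrahydroisoquinolin-2-yl in place of 4,4-dimethylpiperidin-1-yl on a carbonyl carbon. With both measured compounds at the limit, no step beyond the scatter can be read from the data, and nothing indicates that this change should move the read-out. The step from compound 2 to compound 3 is expected to be a step that the limit leaves unreadable from compound 2 to compound 3. Compound 3 is accordingly estimated at 50000 nM, within a range from 15000 nM to 150000 nM, most probably again reported only as a limit.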

Compound 3, half-maximal effective concentration: 29000 nM
Estimate against measurement, compound 3: 1.7-fold (0.24 log units) above; measured number inside the range.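

For the compounds shown here, with 1,2,3,4-tetrahydroisoquinolin-2-yl on the carbonyl carbon, compound 3 gives 29000 nM in this assay, the first number of the series rather than a limit. Compound 1 and compound 2 remain at a limit: the limit of > 40000 nM in this assay, at which 2 of the 3 values shown sit. The change at this position thus gives an at least 1.3-fold lower number from compound 2 to compound 3 (0.13 log units; that floor lies within the scatter), so the data show that this position can bring the read-out onto the measured scale, but they do not establish a step beyond the scatter.

On these data alone, the true size of the step remains open, as does whether the six-membered aromatic ring of carbon only accounts for the measurable value. A morpholin-4-yl or a 4-phenylpiperidin-1-yl group on the same carbonyl carbon would be needed to show how far the read-out follows the amide group at this position.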